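The source may report more compounds than this note shows. Statements on the series, on what has been measured and on what is new or still open speak of the compounds shown alone.

Compound 1 `C=CCCCCOc1ccccc1-c1cnc(OCCCCC=C)n1C`: 7000 nM
Compound 2 `C=CCCCCCOc1ncc(-c2ccccc2OCCCCC=C)n1C`: 76000 nM

In a functional assay on U-373MG ATCC cells (Homo sapiens) for inhibition, read by colorimetric assay and MTT assay, with a stated time of 72 h (a lower number here means a stronger inhibitor, a higher number a weaker inhibitor), compound 2 has the higher number of the two, at 76000 nM. Compound 3 `C=CCCCCOc1ccccc1-c1cnc(OCCOCC=C)n1C` departs from compound 2 in one place: allyloxy in place of pent-4-en-1-yl on a saturated chain carbon, two bonds along the chain from an oxygen on an aromatic ring. Among the measured compounds shown here, the only measured step, an 11-fold higher number from compound 1 to compound 2 (1.04 log units; beyond the scatter), is large and changes the same chain, though it offers no direct precedent for allyloxy. On that evidence, a move to a lower number in this assay, beyond the scatter but smaller than the measured step, is expected: a 5.1-fold lower number from compound 2 to compound 3 (0.70 log units; beyond the scatter). Compound 3 is estimated at 15000 nM, with an expected range of 4000 nM to 60000 nM.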

Compound 3, half-maximal inhibitory concentration: 60000 nM
Compound 3: middle estimate off by 4.0-fold (0.60 log units), on the low side; measured number inside the range.
By their numbers in this assay, from the lowest: compound 1; then compounds 3 and 2 (each within the scatter of the next).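

In this assay, the step from pent-4-en-1-yl to allyloxy at this chain carbon is a 1.3-fold lower number from compound 2 to compound 3 (0.10 log units; within the scatter), so this exchange, which brings in a hydrogen-bond acceptor, does not separate the two compounds. Measured against but-3-en-1-yl, the same allyloxy group gives an 8.6-fold higher number from compound 1 to compound 3 (0.93 log units; beyond the scatter), which shows that the gap to compound 1 remains when the chain contains an oxygen. Nothing available explains these results. Going by these compounds, whether an amine or a carboxylic acid on this chain would bring the number closer to that of compound 1 remains open.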